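The compounds below may be only part of what the source reports. "The series", "measured", "known", "first", "only" and "open" are said of these compounds alone.

Compound 1 `COc1cccc(Oc2ccc3c(NCCCNCc4cc(F)ccc4OC)ccnc3c2)c1` was tested in an ADME assay on HepG2 cells (Homo sapiens) for cytotoxicity, read by luminescence, CellTiter-Glo and ATP content, with a stated time of 72 h (on this read-out lower numbers stand for an effect already at smaller amounts and higher numbers for an effect only at larger amounts of compound), where compound 1 gives 7100 nM. Among the three measured compounds this is the second highest number: compound 3 `COc1cccc(Oc2ccc3c(NCCCNCc4cccc(OC)c4O)ccnc3c2)c1` gives 5300 nM, and compound 2 `COc1cccc(CNCCCNc2ccnc3cc(Oc4ccc(F)cc4)ccc23)c1O` gives 11000 nM, and both of these lie within the scatter of the number for compound 1. Two single changes have been measured. Replacing one group on a saturated chain carbon bound to an amine nitrogen gives a 1.3-fold lower number from compound 1 to compound 3 (0.13 log units; within the scatter). Replacing the group on an oxygen on an aromatic ring gives a 2.1-fold lower number from compound 2 to compound 3 (0.32 log units; beyond the scatter).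

Compound 4 `CCC(CC)c1ccc2c(NCCCNCc3cc(F)ccc3OC)ccnc2c1` differs from compound 1 in one place: pentan-3-yl in place of 3-methoxyphenoxy on an aromatic carbon. Within the data shown here, no measured step removes the whole 3-methoxyphenoxy group; the nearest comparison, the change on an oxygen on an aromatic ring, was only modest. A step of similar size, or none beyond the scatter, is therefore expected. Compound 4 is expected to give 7000 nM, between 3000 nM and 17000 nM. The expected step is a 1.0-fold lower number from compound 1 to compound 4 (0.01 log units; within the scatter).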

Compound 4, half-maximal effective concentration: 7860 nM
The estimate for compound 4 lay 1.1-fold (0.05 log units) below the measured number; the range from low to high includes it.
By their numbers in this assay, from the lowest: compounds 3, 1, 4 and 2 (each within the scatter of the next, the first and the last beyond it).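

Putting pentan-3-yl in place of 3-methoxyphenoxy gives a 1.1-fold higher number from compound 1 to compound 4 (0.04 log units; within the scatter) in this assay. The earlier compounds shown here changed only the group on the oxygen, and each kept an aromatic ring attached through that oxygen. Compound 4 shows that both the oxygen and that ring can leave this aromatic carbon without a change beyond the scatter, even though the entering group has no ring and no hydrogen-bond acceptors. No measurement at hand explains this lack of change.

On these data alone, it remains open whether a carboxylic acid or an amine on this aromatic carbon would shift the number beyond the scatter. As far as these compounds go, it is also open whether pentan-3-yl would give a similar result with the 2-hydroxy-3-methoxyphenyl group of compound 3 on the chain.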